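Replacing an ethyl with a pyrimidinyl on a ring nitrogen

This account rests on a few compounds, and the source may have more. Where it says the series, first, only, none or still open, it means among the compounds named here.

Compound 1 `COc1ccc(C[C@@H](O)/C=C/C=C/C(=O)N2CCN(C)CC2)cc1OC`: 22200 nM
Compound 2 `CCN1CCN(C(=O)/C=C/C=C/[C@H](O)Cc2ccc(OC)c(OC)c2)CC1`: 15700 nM

Both compounds share the same core and were tested in a functional assay on A549 cells (Homo sapiens) for antiproliferative activity, read by sulforhodamine B assay, with a stated time of 48 h; a lower number here means a stronger inhibitor, a higher number a weaker inhibitor. Compound 2 holds the lowest of the two numbers, and its nearest neighbour is compound 1; the step of a 1.4-fold lower number from compound 1 to compound 2 (0.15 log units; within the scatter) is within the scatter, so the two values cannot be ordered.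

Compound 3 `COc1ccc(C[C@@H](O)/C=C/C=C/C(=O)N2CCN(c3ncccn3)CC2)cc1OC` follows from compound 2 by a single change: pyrimidin-2-yl in place of ethyl on an amine nitrogen in a ring. Among the compounds with values here, no measured step touches this ring nitrogen with an aromatic group; the only step known, from ethyl in place of hydrogen, stayed within the scatter. Nothing in these data therefore points to a step beyond the scatter in this assay in either direction, though a larger group at this place leaves the outcome open.

For compound 3 the expected value in this assay is 12000 nM, with a range of 4000 nM to 40000 nM, which means an expected step of a 1.3-fold lower number from compound 2 to compound 3 (0.12 log units; within the scatter).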

Compound 3, half-maximal inhibitory concentration: 9920 nM
For compound 3 the middle estimate is 1.2-fold (0.08 log units) above the measured one; measured number inside the range.
By their numbers in this assay, from the lowest: compounds 3, 2 and 1 (each within the scatter of the next, the first and the last beyond it).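

In this assay the ring nitrogen proved able to carry an aromatic ring, which the methyl and ethyl compounds could not show. Set against ethyl, pyrimidin-2-yl gives a 1.6-fold lower number from compound 2 to compound 3 (0.20 log units; within the scatter), so these two groups cannot be ordered despite the larger group's 6 heavy atoms. Set against methyl, the same group gives a 2.2-fold lower number from compound 1 to compound 3 (0.35 log units; beyond the scatter), a modest step that is the only one here beyond the scatter, and no available evidence gives a reason for it.

Going by these compounds, what remains open is whether the ring nitrogens of pyrimidin-2-yl matter, a question that a phenyl group on this amine nitrogen would address. On these data alone, it is equally open whether a benzyl group or a longer chain at this place would carry the step further, or whether a carboxylic acid would reverse it.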